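Acid to isobutyl ketone: the step from compound 2 to compound 4

The compounds below may be only part of what the source reports. "The series", "measured", "known", "first", "only" and "open" are said of these compounds alone.

Compound 2 `CC(/C=C/CC(C)CCCC(C)C)=C\C(=O)O` is the free acid of this set. In a physicochemical assay for lipophilicity (a lower number here means a more polar compound, a higher number a more lipophilic compound), compound 2 gives 5.95, the lowest of the two single numbers available. Among the measured compounds shown here, the nearest measured neighbour is compound 1 `CCC(C)OC(=O)/C=C(C)/C=C/CC(C)CCCC(C)C`, the sec-butyl ester, which in this assay gives 7.69; the only fully compared step in the set is a number 1.74 log units lower from compound 1 to compound 2 (beyond the scatter). Compound 3 `CCC(=O)/C=C(C)/C=C/CC(C)CCCC(C)C`, the ethyl ketone, carries no single number: in this assay compound 3 gives 6.27; 6.68 (2 entries), and the several entries of compound 3 in this assay, 6.27; 6.68 (2 entries) show how far repeats of this kind can sit apart.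

Compound 4 `CC(/C=C/CC(C)CCCC(C)C)=C\C(=O)CC(C)C` has not yet been measured. It differs from compound 2 by isobutyl in place of hydroxy on a carbonyl carbon. The step from compound 1 to compound 2 is the one that bears on this change, since it too removes a sec-butyl from the acid-derived end and was large. The present change runs the other way, adding four carbons and removing the hydroxy, so an increase in this assay well beyond the scatter is expected. Compound 4 is estimated at 7.5, within 6.9 to 8.1, which means an expected step of a number 1.55 log units higher from compound 2 to compound 4 (beyond the scatter).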

Compound 4, partition coefficient: 7.22
Compound 4: the middle estimate sits 0.28 log units above what was measured; measured number inside the range.
By their numbers in this assay, from the lowest: compound 2; then compound 4; then compound 1.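

In this assay, among the compounds shown here, isobutyl in place of hydroxy on a carbonyl carbon gives a large change (a number 1.27 log units higher from compound 2 to compound 4 (beyond the scatter)), the first step that leaves the acid without passing through an ester. The two groups that replace hydroxy do not end at the same number, since the ketone and the ester remain apart (a number 0.47 log units lower from compound 1 to compound 4 (beyond the scatter)), so the number at this carbonyl carbon depends on what enters and not only on the loss of hydroxy. Of the two steps that involve compound 4, the larger is the one from the acid, which places the isobutyl ketone compound 4 closer to the sec-butyl ester compound 1 than to the free acid compound 2.

Steps to compound 3 cannot be read, so the effect of chain length on the ketone stays unsettled, since the ethyl ketone compound 3 has no single number: the several entries of compound 3 in this assay, 6.27; 6.68 (2 entries). An amide or a longer chain on the same carbonyl carbon would test whether the number follows the group's carbon count or the atom joined to the carbonyl.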